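Methylsulfanyl for Fluoro: Expected Cytotoxicity of Compound 4

The source may report more compounds than this note shows. Statements on the series, on what has been measured and on what is new or still open speak of the compounds shown alone.

Compound 1 `Cc1cc(NC(=O)Nc2ncccc2C)c2ccccc2n1` gives > 25000 nM in an ADME assay on BJ cells (Homo sapiens) for cytotoxicity, with a stated time of 72 h; a lower number here means that less compound is needed, a higher number that more compound is needed for the effect.
Compound 2 `Cc1cc(NC(=O)Nc2cccc(Cl)c2)c2ccccc2n1` gives > 25000 nM in this assay.
Compound 3 `Cc1cc(NC(=O)Nc2ccc(F)cc2)c2ccccc2n1` gives > 25000 nM in this assay.

Each of these three values is a limit of the assay, not a number, and all three sit at the same place (the limit of > 25000 nM in this assay, at which 3 of the 3 values shown sit). Because of this, the step that the two limits leave unreadable from compound 1 to compound 2 cannot be read, and the same holds for a step that the two limits leave unreadable from compound 1 to compound 3 and a step that the two limits leave unreadable from compound 2 to compound 3. Within the data shown here, compound 3 therefore stands at the limit, with no measured step anywhere among the three compounds that could point in either direction.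

Compound 4 `CSc1ccc(NC(=O)Nc2cc(C)nc3ccccc23)cc1` differs from compound 3 in one place: methylsulfanyl in place of fluoro on an aromatic carbon. Among the measured compounds shown here, none of the three measured steps bears a readable size, so no step beyond the scatter can be expected from them; the shared core and urea are kept, and the only evidence is that every measured compound remains at the limit.

Compound 4 is therefore expected to give about 30000 nM in this assay, within an expected range from 12000 nM to 80000 nM. This expectation amounts to a step that the limit leaves unreadable from compound 3 to compound 4.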

Compound 4, half-maximal effective concentration: > 25000 nM
Compound 4: a limit, no number; the forecaster's own chance of this, stated with the estimate: 80%; the middle value does not contradict the limit.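

Compound 3 and compound 4 each give a limit and not a number, so no step between them can be read, and all four compounds sit at one place: the limit of > 25000 nM in this assay, at which 4 of the 4 values shown sit.

The compounds shown leave open where the true values lie in this assay, and whether methylsulfanyl and fluoro differ there at all.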